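A few compounds are considered here, and "the series" means these few. Any claim that something is new, unique, unknown or untested is made for them only; others in the source may bear on it.

Compound 1, with structure `Cc1ccc(-n2cc(C(=O)Nc3cc(F)cc(F)c3)c(=O)c3ccc(N(C)C)nc32)cc1OCCCCCCC[N+]1(C)CCCCC1`, was tested in an assay on LX2 cells for inhibition of COL1A1 promoter (Homo sapiens), read by a luciferase reporter, with a stated time of 24 h, tested at 20 uM (a lower number here means a weaker effect, a higher number a stronger effect of the compound at the concentration tested), and there compound 1 gives 23.4%. Compound 2, with structure `CN(C)c1ccc2c(=O)c(C(=O)Nc3cc(F)cc(F)c3)cn(-c3ccc(Cl)c(OCCCCCCC[N+]4(C)CCCCC4)c3)c2n1`, carries chloro in place of methyl on an aromatic carbon and otherwise matches compound 1; in this assay compound 2 gives 57.3%. For the measured compounds named here, the step of a number 33.9 percentage points higher from compound 1 to compound 2 (beyond the scatter) is the one counted change between these two, and it is large.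

Compound 3 has structure `CC[N+]1(CCCCCCCOc2ccc(-n3cc(C(=O)Nc4cc(F)cc(F)c4)c(=O)c4ccc(N(C)C)nc43)c(C)c2)CCCCC1`. The difference between the core of compound 3 and the core of compound 1 is not broken down here. In this assay compound 3 gives "not active" (no number reported), so no number stands for it.

Compound 4, with structure `CC[N+]1(CCCCCCCOc2ccc(-n3cc(C(=O)Nc4cc(F)cc(F)c4)c(=O)c4ccc(N(C)C)nc43)c(Cl)c2)CCCCC1`, is not yet measured in this assay. It is made from compound 3 by chloro in place of methyl on an aromatic carbon. Both steps, compound 1 to compound 2 and compound 3 to compound 4, place the chloro on an aromatic carbon of a six-membered aromatic ring of carbon only, ortho to a large group; in the first the place is also para to a large group, in the second meta to a large group, so the two are the same kind of change, not the same.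

With compound 3 reporting no number, the expected size of the step to compound 4 rests only on the large gain shown in a number 33.9 percentage points higher from compound 1 to compound 2 (beyond the scatter), and a gain of the same kind, though not the same, is expected. For compound 4 in this assay the estimated value is 30%, expected to fall between 5% and 60%.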

Compound 4, a percentage reported as inhibition, at one concentration (the size of the read-out at that concentration, not a potency): "not active" (no number reported)
The entry for compound 4 holds no number; the estimate stays without a comparison.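

In this assay, for the compounds shown here, compound 3 gives "not active" (no number reported) and compound 4 gives "not active" (no number reported) so no step from one to the other can be read. No measurement shown here bears on this result. The compounds shown leave open whether chloro in place of methyl on this aromatic carbon changes the read-out at all when the starting compound gives no number.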